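Swapping the Chloro Group of Compound 1 for Hydroxymethyl

A few compounds are considered here, and "the series" means these few. Any claim that something is new, unique, unknown or untested is made for them only; others in the source may bear on it.

Compound 1 `O=c1cc(Cl)c2ccc(OCc3cccc(Cl)c3)cc2o1` gives 8910 nM in an assay on isolated protein (strain Sprague-Dawley) for inhibition of Amine oxidase [flavin-containing] A (Rattus norvegicus), read by spectrophotometry, with a stated time of 5 min; on this read-out lower numbers stand for stronger inhibition and higher numbers for weaker inhibition.
Compound 2 `CNc1cc(=O)oc2cc(OCc3cccc(Cl)c3)ccc12` gives 4070 nM in this assay.
Compound 3 `CCNc1cc(=O)oc2cc(OCc3cccc(Cl)c3)ccc12` gives 9330 nM in this assay.

Among these three numbers compound 1 stands second highest. Its nearest number is that of compound 3 and its furthest that of compound 2: a 1.0-fold higher number from compound 1 to compound 3 (0.02 log units; within the scatter), while a 2.2-fold lower number from compound 1 to compound 2 (0.34 log units; beyond the scatter).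

Compound 4 `O=c1cc(CO)c2ccc(OCc3cccc(Cl)c3)cc2o1` differs from compound 1 by hydroxymethyl in place of chloro on an aromatic carbon. Two measured steps replace that same chloro group: a 2.2-fold lower number from compound 1 to compound 2 (0.34 log units; beyond the scatter), a modest shift, and a 1.0-fold higher number from compound 1 to compound 3 (0.02 log units; within the scatter), which stayed within the scatter. Neither replacement moved the number far, so compound 4 is expected to sit close to compound 1 in this assay, with no step beyond the scatter. For compound 4 this expectation means a 1.2-fold lower number from compound 1 to compound 4 (0.07 log units; within the scatter). Compound 4 is therefore estimated at 7500 nM, ranging between 2500 nM and 22000 nM.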

Compound 4, half-maximal inhibitory concentration: 10200 nM
For compound 4 the middle estimate is 1.4-fold (0.13 log units) below the measured one, within the range that was stated.
By their numbers in this assay, from the lowest: compound 2; then compounds 1, 3 and 4 (each within the scatter of the next).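

In this assay hydroxymethyl on this aromatic carbon, opposite the ring oxygen, reads level with chloro (a 1.1-fold higher number from compound 1 to compound 4 (0.06 log units; within the scatter)) and with ethylamino (a 1.1-fold higher number from compound 3 to compound 4 (0.04 log units; within the scatter)), while methylamino alone stands apart (a 2.5-fold higher number from compound 2 to compound 4 (0.40 log units; beyond the scatter)). The hydrogen-bond donor and acceptor that hydroxymethyl counts and chloro lacks thus leave the number within the scatter. Nothing measured here explains why methylamino alone differs.

As far as these compounds go, whether a free amine, a carboxylic acid or a longer chain at this position would take the number beyond the scatter of compound 1 stays open. So does whether methylamino keeps its edge on a different core.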